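Methoxy in place of bromo on the pendant phenyl ring

The source may report more compounds than this note shows. Statements on the series, on what has been measured and on what is new or still open speak of the compounds shown alone.

compound 1 `Cn1cc(C2CC(c3ccccc3)=NN2C(=O)c2cccnc2)c2cc(Br)ccc21`: 1520 nM
compound 2 `Cn1cc(C2CC(c3ccc(Cl)cc3)=NN2C(=O)c2cccnc2)c2cc(Br)ccc21`: 8100 nM
compound 3 `Cn1cc(C2CC(c3ccc(Br)cc3)=NN2C(=O)c2cccnc2)c2cc(Br)ccc21`: 11800 nM

In a functional assay on MCF7 cells (Homo sapiens) for inhibition, read by MTT assay, with a stated time of 48 h (on this read-out higher numbers stand for weaker inhibition of growth and lower numbers for stronger inhibition of growth), compound 3 has the highest number of the three. It sits within the scatter of compound 2 (a 1.5-fold higher number from compound 2 to compound 3 (0.16 log units; within the scatter)), but well apart from compound 1 (a 7.8-fold higher number from compound 1 to compound 3 (0.89 log units; beyond the scatter)). Compound 4 `COc1ccc(C2=NN(C(=O)c3cccnc3)C(c3cn(C)c4ccc(Br)cc34)C2)cc1` differs from compound 3 by methoxy in place of bromo on an aromatic carbon. The measured steps bearing on this position are a 5.3-fold higher number from compound 1 to compound 2 (0.73 log units; beyond the scatter) and a 7.8-fold higher number from compound 1 to compound 3 (0.89 log units; beyond the scatter): both halogens gave a higher number than hydrogen. Within the data shown here, no measured step involves methoxy, so its direction is not fixed by the data. Compound 4 is therefore estimated at a middling number, a 2.4-fold lower number from compound 3 to compound 4 (0.37 log units; beyond the scatter), placing compound 4 at 5000 nM with a range of 1500 nM to 15000 nM.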

Compound 4, concentration for 50% growth inhibition: 1560 nM
The estimate for compound 4 lay 3.2-fold (0.51 log units) above the measured number; low and high end bracket the measured number.
By their numbers in this assay, from the lowest: compounds 1 and 4 (each within the scatter of the next); then compounds 2 and 3 (each within the scatter of the next).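

In this assay, methoxy at this position parts from both halogens (a 7.6-fold lower number from compound 3 to compound 4 (0.88 log units; beyond the scatter); a 5.2-fold lower number from compound 2 to compound 4 (0.72 log units; beyond the scatter)). It shows no difference from the hydrogen of compound 1 (a 1.0-fold higher number from compound 1 to compound 4 (0.01 log units; within the scatter)), so among these compounds, the higher number goes with chloro and bromo, not with every replacement of hydrogen on this aromatic carbon. Nothing at hand explains why methoxy and the halogens part here. From the compounds shown here alone, it remains open whether an amine, a carboxylic acid or a longer chain such as ethoxy in this place would read like methoxy or like the halogens.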